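This account rests on a few compounds, and the source may have more. Where it says the series, first, only, none or still open, it means among the compounds named here.

In a physicochemical assay for solubility, with a stated time of 24 h, tested at 30 mg/mL (a higher number here means a more soluble compound, a lower number a less soluble compound), compound 1 (`Cc1cc(COc2ccc(S(=O)(=O)NCCC(=O)NO)cc2)c2ccccc2n1`) gives 4100000 nM. This is level, within the scatter, with compound 2 (`CCCCN1CC(CC(=O)NO)(NS(=O)(=O)c2ccc(OCc3cc(C)nc4ccccc34)cc2)C1`) at 4900000 nM, while compound 3 (`Cc1cc(COc2ccc(S(=O)(=O)NC3(CC(=O)NO)CN(C(=O)C(C)(C)N(C)C)C3)cc2)c2ccccc2n1`) stands higher at 11000000 nM. Compound 1 therefore sits at the lower end of this small set, though not clearly apart from compound 2.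

Compound 4 (`Cc1cc(COc2ccc(S(=O)(=O)NCC(=O)NO)cc2)c2ccccc2n1`), not yet measured, differs from compound 1 in one place: hydroxycarbamoyl in place of (hydroxycarbamoyl)methyl on a saturated chain carbon bound to a sulfonamide nitrogen. Hydroxycarbamoyl takes the place of (hydroxycarbamoyl)methyl on a saturated chain carbon bound to a sulfonamide nitrogen. Cut one bond further out, this reads as 2-(hydroxycarbamoyl)ethyl going to (hydroxycarbamoyl)methyl.

For the measured compounds named here, the only single-place step measured so far is a 2.2-fold higher number from compound 2 to compound 3 (0.35 log units; beyond the scatter). That step is modest and involves a different change, with (1-(dimethylamino)-1-methylethyl)carbonyl in place of butyl on an amine nitrogen in a ring. Going by the values given here, no measured step alters the chain that changes here, so the data offer only indirect guidance. Among the compounds with values here, with no measured precedent for a larger shift, no change beyond the scatter is expected in this assay, in either direction. The estimated step is a 1.0-fold lower number from compound 1 to compound 4 (0.01 log units; within the scatter). Compound 4 is expected at 4000000 nM, with an estimated range of 2000000 nM to 8000000 nM.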

Compound 4, solubility: 100000 nM
Beside the measured number, compound 4's estimate is 40-fold (1.60 log units) above it; measured number below the stated range.
By their numbers in this assay, from the lowest: compound 4; then compounds 1 and 2 (each within the scatter of the next); then compound 3.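

In this assay, for the compounds shown here, the chain on the sulfonamide nitrogen proves to be a sensitive place, with the change giving a 41-fold lower number from compound 1 to compound 4 (1.61 log units; beyond the scatter) and standing well apart from the only other single-place step, a 2.2-fold higher number from compound 2 to compound 3 (0.35 log units; beyond the scatter) which lies in a different part of the molecule. The group that enters, hydroxycarbamoyl, has 4 heavy atoms against 5 for the (hydroxycarbamoyl)methyl that leaves, while both have the same count of hydrogen-bond donors and acceptors, no ring and no net charge, so this large step goes with a shortening of the chain and with none of those other counted differences. Nothing measured here explains the size of the step.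

The compounds shown leave open whether a longer chain, such as 3-(hydroxycarbamoyl)propyl, would keep the number near that of compound 1 or shift it again. They also leave open how a carboxylic acid or an amine in place of hydroxycarbamoyl would read at this position, and whether the same shortening would have a similar effect in compound 2 or compound 3.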